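The compounds below may be only part of what the source reports. "The series", "measured", "known", "first", "only" and "open" are said of these compounds alone.

Measured compounds:
Compound 1 `COc1ccc(-c2cnc3nc(N)nc(N4CCN(C(=O)NCc5ccccc5)CC4)c3n2)cc1OC` gives 18 nM in a functional assay on cells (T-cell, Homo sapiens) for inhibition; on this read-out lower numbers stand for stronger inhibition and higher numbers for weaker inhibition.
Compound 2 `COc1ccc(-c2cnc3nc(N)nc(N4CCN(c5ccc(C)cc5)CC4)c3n2)cc1OC` gives 300 nM in this assay.
Compound 3 `COc1ccc(-c2cnc3nc(N)nc(N4CCN(C(=O)Nc5cccc(C)c5)CC4)c3n2)cc1OC` gives 7 nM in this assay.

Compound 3 has the lowest number of the three and so the strongest inhibition, standing apart from both others: a 2.6-fold lower number from compound 1 to compound 3 (0.41 log units; beyond the scatter) and a 43-fold lower number from compound 2 to compound 3 (1.63 log units; beyond the scatter). Compound 4 `COc1ccc(-c2cnc3nc(N)nc(N4CCN(C(=O)CCc5ccccc5)CC4)c3n2)cc1OC` differs from compound 3 in one place: phenethyl in place of (3-methylphenyl)amino on a carbonyl carbon. The closest guide is the modest step of a 2.6-fold lower number from compound 1 to compound 3 (0.41 log units; beyond the scatter), where only the group on the amide-type nitrogen changed. The large steps of a 17-fold higher number from compound 1 to compound 2 (1.22 log units; beyond the scatter) and a 43-fold lower number from compound 2 to compound 3 (1.63 log units; beyond the scatter) came when a carbamoyl group was exchanged for 4-methylphenyl, a different kind of change. A small upward step is therefore expected: a 2.9-fold higher number from compound 3 to compound 4 (0.46 log units; beyond the scatter). Compound 4 is estimated at 20 nM, within a range from 6 nM to 70 nM.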

Compound 4, half-maximal inhibitory concentration: 100 nM
For compound 4 the middle estimate is 5.0-fold (0.70 log units) below the measured one; measured number outside the range, above it.
By their numbers in this assay, from the lowest: compound 3; then compound 1; then compound 4; then compound 2.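

In this assay, exchanging (3-methylphenyl)amino for phenethyl on the carbonyl carbon keeps the heavy-atom count but removes a hydrogen-bond donor, and the number rises sharply: a 14-fold higher number from compound 3 to compound 4 (1.15 log units; beyond the scatter). The benzylamino comparison points the same way, a 5.6-fold higher number from compound 1 to compound 4 (0.74 log units; beyond the scatter), while phenethylcarbonyl still gives a lower number than 4-methylphenyl on the ring nitrogen, a 3.0-fold lower number from compound 2 to compound 4 (0.48 log units; beyond the scatter). Nothing available explains these differences. The compounds shown leave open whether the nitrogen on the carbonyl carbon itself matters. A benzyloxy or phenoxy group at this place could help separate that nitrogen from the rest of the group.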